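Notes on the sulfonyl amine substituent in the series

A few compounds are considered here, and "the series" means these few. Any claim that something is new, unique, unknown or untested is made for them only; others in the source may bear on it.

Measured so far:
compound 1, `C=CCN(CC=C)S(=O)(=O)NC(=O)Nc1c(C(C)C)cccc1C(C)C`, 2700 nM
compound 2, `CCCCN(CC)S(=O)(=O)NC(=O)Nc1c(C(C)C)cccc1C(C)C`, 1200 nM

Both compounds were tested in an assay on liver for inhibition of sterol O-acyltransferase 1 (Rattus norvegicus), using microsomes; a lower number here means a stronger inhibitor, a higher number a weaker inhibitor. Compound 2 gives the lowest number of the two in this assay, and the nearest is compound 1, which stands higher by a 2.3-fold lower number from compound 1 to compound 2 (0.35 log units; beyond the scatter). Among the measured compounds shown here, that is the only step measured so far: butyl(ethyl)amino in place of diallylamino on a sulfonyl sulfur, a modest step beyond the scatter.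

Compound 3, `CC(C)c1cccc(C(C)C)c1NC(=O)NS(=O)(=O)N(C(C)C)C(C)(C)C`, is not yet measured. It differs from compound 2 as follows: isopropyl(tert-butyl)amino in place of butyl(ethyl)amino on a sulfonyl sulfur. For the measured compounds named here, only the step from compound 1 to compound 2 bears on this change, and it is a loose comparison, since it concerns a different pair of groups at the same place. It shows that exchanging the two groups on the sulfonyl nitrogen can move the number by a 2.3-fold lower number from compound 1 to compound 2 (0.35 log units; beyond the scatter). The step from compound 2 to compound 3 is therefore expected to be small, in either direction, with a slight lean toward a lower number. For compound 3, a value of 900 nM is estimated in this assay, within 300 nM to 2700 nM, corresponding to an expected step of a 1.3-fold lower number from compound 2 to compound 3 (0.12 log units; within the scatter).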

Compound 3, half-maximal inhibitory concentration: 140 nM
Compound 3: the middle estimate sits 6.4-fold (0.81 log units) above what was measured, outside the stated range (below it).
By their numbers in this assay, from the lowest: compound 3; then compound 2; then compound 1.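

Notes on the result at the sulfonyl amine position

In this assay, among the compounds shown here, this position proves far more responsive than the earlier pair suggested: the only previous step was a 2.3-fold lower number from compound 1 to compound 2 (0.35 log units; beyond the scatter), whereas isopropyl(tert-butyl)amino in place of butyl(ethyl)amino gives an 8.6-fold lower number from compound 2 to compound 3 (0.93 log units; beyond the scatter) on the same shared core. Set against diallylamino, the same group gives a 19-fold lower number from compound 1 to compound 3 (1.29 log units; beyond the scatter) and makes compound 3 the strongest inhibitor of the three, so the choice of the two groups on this nitrogen can alter the number substantially with the rest of the structure held constant. No supporting measurement is available to explain the size of this change.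

The compounds shown leave open whether the isopropyl group, the tert-butyl group or only their combination accounts for the lower number in compound 3, since both groups differ from those in compound 2 at once. From the compounds shown here alone, how diisopropylamino, tert-butyl(ethyl)amino or a cyclic amine such as piperidine would compare at this place on the sulfonyl sulfur also remains open, and these would help separate the contributions.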